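The source may report more compounds than this note shows. Statements on the series, on what has been measured and on what is new or still open speak of the compounds shown alone.

Measured compounds:
compound 1 `CC(C)c1ccc(NC(=O)N[C@@H](C)c2ccccc2)cc1` — 86%
compound 2 `CCCc1ccc(NC(=O)N[C@H](C)c2ccccc2)cc1` — 35%

In an ADME assay on the whole organism with Oryza sativa as the target, tested at 10 uM (a lower number here means a stronger effect, a higher number a weaker effect of the compound at the concentration tested), compound 2 gives 35%, the lowest of the two numbers; the nearest is compound 1, whose reading in this assay, 86%, is higher by an amount beyond the scatter. Since these two compounds differ in more than one place, no single step between them can be read off, and what configuration alone does is not shown by any measured pair.

Compound 3 `CCCc1ccc(NC(=O)N[C@@H](C)c2ccccc2)cc1` remains to be measured in this assay. From compound 2 the change is the two compounds have the same atoms and bonds and differ only in configuration as drawn: 1 of 1 stereo elements differ; a stereocentre at a saturated chain carbon is drawn R in compound 2 and S in compound 3. For the measured compounds named here, with no measured step of this kind, the expectation rests on compound 1, which shares the configuration now drawn for compound 3. In this assay compound 1 gives 86%, so a rise beyond the scatter, toward a weaker effect, is expected, with wide uncertainty. The expected step from compound 2 to compound 3 is a number 30 percentage points higher from compound 2 to compound 3 (beyond the scatter). In this assay compound 3 is estimated at 65%, within 35% to 95%.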

Compound 3, a percentage reported as activity, at one concentration (the size of the read-out at that concentration, not a potency): 73%
Beside the measured number, compound 3's estimate is 8 percentage points below it; the range from low to high includes it.
By their numbers in this assay, from the lowest: compound 2; then compound 3; then compound 1.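

In this assay, the configuration at the saturated chain carbon now has a measured step of its own: drawing it S rather than R gives a number 38 percentage points higher from compound 2 to compound 3 (beyond the scatter), a large change toward a weaker effect. With the S configuration held, propyl in place of isopropyl on an aromatic carbon gives a number 13 percentage points lower from compound 1 to compound 3 (beyond the scatter), a modest step beside the one for configuration, so at this stage the stereocentre carries the larger change of the two. The first step can be assigned to configuration alone because nothing else changes: the fact that compounds 2 and 3 differ only in the configuration as drawn

Going by these compounds, whether a step of similar size and direction holds with isopropyl on the aromatic carbon remains open. Also open, on these data alone, is how a longer chain, an amine or a carboxylic acid at that aromatic carbon would read in this assay under either configuration.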